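Losing the Carboxy Group from Compound 3

The source may hold more compounds than are shown below. What is called first, only, known or untested is meant among the compounds shown, and "the series" means these compounds.

- Compound 1 `COc1ccc(/C=C\c2cc(OC)c(OC)c(OC)c2)cc1OCc1ccc(C=O)cc1`: 4800 nM
- Compound 2 `COc1ccc(/C=C\c2cc(OC)c(OC)c(OC)c2)cc1OCc1ccc(CN2CCCC[C@@H]2C(=O)O)cc1`: > 10000 nM, a limit of the assay
- Compound 3 `COc1ccc(/C=C\c2cc(OC)c(OC)c(OC)c2)cc1OCc1ccc(CN2CC[C@H](C(=O)O)C2)cc1`: > 10000 nM, a limit of the assay

All three compounds were tested in a functional assay on HeLa cells (Homo sapiens) for antiproliferative activity, read by CCK-8 assay, with a stated time of 48 h; on this read-out higher numbers stand for weaker inhibition and lower numbers for stronger inhibition. Compound 3 has no exact number, only the limit > 10000 nM. It shares this position with one other compound, as the limit of > 10000 nM in this assay, at which 2 of the 3 values shown sit, shows.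

Compound 4 `COc1ccc(/C=C\c2cc(OC)c(OC)c(OC)c2)cc1OCc1ccc(CN2CC[C@H](O)C2)cc1` differs from compound 3 in one place: hydroxy in place of carboxy on a saturated ring carbon. In words, hydroxy stands in place of carboxy on a saturated ring carbon, turning 3-carboxypyrrolidin-1-yl into 3-hydroxypyrrolidin-1-yl.

Among the measured compounds shown here, no measured step removes a carboxy group directly, so the evidence is indirect. Two steps add one while replacing formyl: an at least 2.0-fold higher number from compound 1 to compound 2 (0.31 log units; beyond the scatter) and an at least 2.0-fold higher number from compound 1 to compound 3 (0.31 log units; beyond the scatter). Both lie beyond the scatter, and both end at a limit. The step that the two limits leave unreadable from compound 2 to compound 3 adds nothing further. Compound 1, which has no carboxy group, gives a real number, 4800 nM. Compound 4 also lacks carboxy, so a modest move towards lower numbers in this assay is expected, though a second limit remains possible.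

The estimate amounts to an expected at least 2.0-fold lower number from compound 3 to compound 4 (0.30 log units; that floor lies within the scatter). For compound 4 the expected value is 5000 nM, with an estimated range of 1200 nM to 18000 nM.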

Compound 4, half-maximal inhibitory concentration: 10500 nM
Estimate against measurement, compound 4: 2.1-fold (0.32 log units) below; the measured number falls inside the stated range.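

Hydroxy in place of carboxy on this saturated ring carbon yields an exact number where the carboxy compounds gave none: in this assay, compound 4 gives 10500 nM. This does not show that removing carboxy improves activity, and the steps from compound 3 and from compound 2 to compound 4 cannot be read, because both starting compounds sit at a limit of the assay: the limit of > 10000 nM in this assay, at which 2 of the 4 values shown sit. The comparison with the formyl compound can be read, and (3-hydroxypyrrolidin-1-yl)methyl in place of formyl gives a 2.2-fold higher number from compound 1 to compound 4 (0.34 log units; beyond the scatter), the first exact size for a replacement of formyl in this set, and one that points to weaker inhibition.

From the compounds shown here alone, how much carboxy itself contributes remains open, as the true number for compound 3 could lie close to that of compound 4 or far from it. The compounds shown also leave open how an amine, a methoxy group or a methyl ester would behave on the same ring carbon, and whether a pyrrolidin-1-yl group with no substituent there would restore or further weaken inhibition.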